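Pyrazolyl in place of dimethylaminomethyl on the compound 3 core

The source may hold more compounds than are shown below. What is called first, only, known or untested is meant among the compounds shown, and "the series" means these compounds.

Three compounds carry numbers in an assay on isolated protein for inhibition of lysine-specific demethylase 5C (Homo sapiens), read by AlphaScreen, with stated times of 15 min and 20 min; on this read-out higher numbers stand for weaker inhibition and lower numbers for stronger inhibition. Compound 1 `O=C(O)c1ccnc(CNCc2ccccc2)c1` gives 60 nM, compound 2 `O=c1[nH]cnc2c(-c3cscn3)nccc12` gives 830 nM, and compound 3 `CN(C)Cc1nccc2c(=O)[nH]cnc12` gives 8400 nM, the highest of the three. For the measured compounds named here, the only single-point step measured is a 10-fold higher number from compound 2 to compound 3 (1.01 log units; beyond the scatter), and it bears directly on the next change. Compound 4 `O=c1[nH]cnc2c(-n3cccn3)nccc12` differs from compound 3 by 1H-pyrazol-1-yl in place of (dimethylamino)methyl on an aromatic carbon. Because the step of a 10-fold higher number from compound 2 to compound 3 (1.01 log units; beyond the scatter) went with the loss of a five-membered aromatic ring, a step back in the opposite direction and of comparable size is expected, as a 5.6-fold lower number from compound 3 to compound 4 (0.75 log units; beyond the scatter). Compound 4 is therefore estimated at 1500 nM, with a range of 500 nM to 5000 nM; the ring differs from that in compound 2, so a full return is not assumed.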

Compound 4, half-maximal inhibitory concentration: 9400 nM
Compound 4: middle estimate off by 6.3-fold (0.80 log units), on the low side; measured number outside the range, above it.
By their numbers in this assay, from the lowest: compound 1; then compound 2; then compounds 3 and 4 (each within the scatter of the next).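

At this position, on an aromatic carbon next to the ring nitrogen, having a five-membered aromatic ring is not enough to give the lower number: with 1H-pyrazol-1-yl there is a 1.1-fold higher number from compound 3 to compound 4 (0.05 log units; within the scatter), so this ring and (dimethylamino)methyl cannot be told apart. The two five-membered rings do separate, with an 11-fold higher number from compound 2 to compound 4 (1.05 log units; beyond the scatter), so what counts here is which ring is attached and not merely that one is present.

Still open, as far as these compounds go, is whether a pyrazole joined through carbon, a phenyl ring or a carboxylic acid at this position would match 1,3-thiazol-4-yl. No measurement given here accounts for the gap between the two rings.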